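A few compounds are considered here, and "the series" means these few. Any claim that something is new, unique, unknown or untested is made for them only; others in the source may bear on it.

Working notes on the series. The shared core carries a propenamide on a pyranone; compound 1 `COc1ccc(CNC(=O)/C=C/c2coc3cc(OC)ccc3c2=O)cc1` has methoxy groups at both ends. In a functional assay on Huh-7 cells (Homo sapiens) for inhibition, read by MTT assay, with a stated time of 48 h (a lower number here means a stronger inhibitor, a higher number a weaker inhibitor), compound 1 gives 7570 nM, which is the second highest of the three numbers at hand: nearest to it is compound 2 `COc1ccc(CNC(=O)/C=C/c2coc3cc(O)ccc3c2=O)cc1`, which gives 8430 nM, and furthest is compound 3 `O=C(/C=C/c1coc2cc(O)ccc2c1=O)Nc1ccccc1`, which gives 3880 nM. Among the measured compounds shown here, the one step measured in one place, a 1.1-fold higher number from compound 1 to compound 2 (0.05 log units; within the scatter), shows that freeing the phenolic oxygen does not move the number. Compound 4 `COc1ccc2c(=O)c(/C=C/C(=O)Nc3cccc(C)c3)coc2c1` has not yet been measured; it differs from compound 1 by 3-methylphenyl in place of 4-methoxybenzyl on an amide-type nitrogen. For the measured compounds named here, no measured step covers this change directly. The nearest comparison is between compound 2 and compound 3, which share the free phenol and differ at the amide nitrogen; compound 3, with a plain phenyl there, sits at the lower number of the two. On that basis a modest move toward a lower number is expected for compound 4, of about a 1.8-fold lower number from compound 1 to compound 4 (0.26 log units; within the scatter), though a result within the scatter would not surprise. Compound 4 is therefore estimated at 4200 nM in this assay, with a range from 2000 nM to 9000 nM.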

Compound 4, half-maximal inhibitory concentration: 15500 nM
Compound 4: middle estimate off by 3.7-fold (0.57 log units), on the low side; the measured number lies above the stated range.
By their numbers in this assay, from the lowest: compounds 3, 1, 2 and 4 (each within the scatter of the next, the first and the last beyond it).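

In this assay, the amide-type nitrogen proves to be a position where the number can move: a 2.0-fold higher number from compound 1 to compound 4 (0.31 log units; beyond the scatter), a modest change but one beyond the scatter, whereas the earlier one-place step on the aromatic oxygen, a 1.1-fold higher number from compound 1 to compound 2 (0.05 log units; within the scatter), stayed within it. The exchange of 4-methoxybenzyl for 3-methylphenyl also shows that an aromatic ring attached to this nitrogen does not by itself bring a lower number, even though compound 2 at 8430 nM and compound 3 at 3880 nM had pointed the other way on the free phenol. Nothing at hand gives a measured property that would account for this step.

The change replaces a group of 9 heavy atoms carrying 1 hydrogen-bond acceptor with one of 7 heavy atoms carrying none, so the compounds shown leave open which part of that exchange, including the methyl on the new ring, carries the step. Also open, going by these compounds, is how the number responds on this nitrogen to a longer chain such as 2-phenylethyl, or to an amine such as a piperidine on a short chain.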